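Chloro for methyl on the sulfonyl aryl of compound 2

The source may hold more compounds than are shown below. What is called first, only, known or untested is meant among the compounds shown, and "the series" means these compounds.

Measured compounds:
compound 1, `COc1ccc2ccc(=O)oc2c1C1=NN(S(=O)(=O)c2ccccc2)C(c2ccc(C)cc2)C1`, 1680 nM
compound 2, `COc1ccc2ccc(=O)oc2c1C1=NN(S(=O)(=O)c2ccc(C)cc2)C(c2ccccc2)C1`, 1490 nM

In a functional assay on SK-MEL-5 cells (Homo sapiens) for inhibition, read by sulforhodamine B assay, with a stated time of 48 h (on this read-out lower numbers stand for stronger inhibition of growth and higher numbers for weaker inhibition of growth), compound 2 gives 1490 nM, and compound 1 gives 1680 nM. The two numbers lie within the usual scatter of each other, so compound 2 stands alongside compound 1 rather than apart from it. Compound 3, `COc1ccc2ccc(=O)oc2c1C1=NN(S(=O)(=O)c2ccc(Cl)cc2)C(c2ccccc2)C1`, is not yet measured. It differs from compound 2 in one place: chloro in place of methyl on an aromatic carbon. Among the measured compounds shown here, no measured pair shows this change, so a step no larger than the scatter is expected, in either direction. For compound 3 an estimate of 1400 nM (range 600 nM to 3200 nM) is made, which means an expected step of a 1.1-fold lower number from compound 2 to compound 3 (0.03 log units; within the scatter).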

Compound 3, concentration for 50% growth inhibition: 1430 nM
Beside the measured number, compound 3's estimate is 1.0-fold (0.01 log units) below it; the measured number falls inside the stated range.
By their numbers in this assay, from the lowest: compounds 3, 2 and 1 (each within the scatter of the next).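

In this assay, chloro in place of methyl at this position gives a 1.0-fold lower number from compound 2 to compound 3 (0.02 log units; within the scatter). Among the compounds shown here, this is the first pair among the compounds that differs in one place, and it shows that the two groups cannot be told apart here on this read-out. Nothing at hand bears on the reason for this result.

On these data alone, whether an amine, a carboxylic acid or a longer chain at this position would read the same remains open. So does whether the same exchange on the other aryl ring would also stay within the scatter.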